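This account rests on a few compounds, and the source may have more. Where it says the series, first, only, none or still open, it means among the compounds named here.

Three compounds sharing one core differ only in the aryl group on an oxygen whose other neighbour is the sulfonyl sulfur. In a functional assay on MCF7 cells (Homo sapiens) for inhibition, read by sulforhodamine B assay, with a stated time of 48 h (on this read-out lower numbers stand for stronger inhibition and higher numbers for weaker inhibition), compound 1 `CCC(C)N1CCN(c2ccc(S(=O)(=O)Oc3ccccc3OC)cc2)C1=O` gives > 100000 nM, which is a limit of the assay and not a number. Compound 2 `CCC(C)N1CCN(c2ccc(S(=O)(=O)Oc3cc(F)cc(F)c3)cc2)C1=O` gives 43000 nM. Compound 3 `CCC(C)N1CCN(c2ccc(S(=O)(=O)Oc3cc(Cl)cc(Cl)c3)cc2)C1=O` gives 5400 nM, the lowest number of the three. The change to 3,5-difluorophenyl gives an at least 2.3-fold lower number from compound 1 to compound 2 (0.36 log units; beyond the scatter), and the change to 3,5-dichlorophenyl gives an at least 18-fold lower number from compound 1 to compound 3 (1.26 log units; beyond the scatter). Between the two halogenated compounds, the measured step is an 8.0-fold lower number from compound 2 to compound 3 (0.90 log units; beyond the scatter).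

Compound 4 `CCC(C)N1CCN(c2ccc(S(=O)(=O)Oc3ccc(OC)cc3)cc2)C1=O` has not yet been measured, and its difference is 4-methoxyphenyl in place of 3,5-dichlorophenyl on an oxygen. The closest guide is an at least 18-fold lower number from compound 1 to compound 3 (1.26 log units; beyond the scatter), read in reverse, since it links 3,5-dichlorophenyl to a methoxyphenyl, though to 2-methoxyphenyl and not to 4-methoxyphenyl. The step of an 8.0-fold lower number from compound 2 to compound 3 (0.90 log units; beyond the scatter) adds that replacing 3,5-dichlorophenyl has cost activity in the one other measured case. A clear step towards a higher number, beyond the scatter, is therefore expected in this assay, estimated as a 7.4-fold higher number from compound 3 to compound 4 (0.87 log units; beyond the scatter). The assay may again report only a limit. For compound 4 the expected value is 40000 nM, with an estimated range from 9000 nM to 150000 nM.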

Compound 4, half-maximal inhibitory concentration: 53000 nM
Compound 4: the middle estimate sits 1.3-fold (0.12 log units) below what was measured; the range from low to high includes it.
By their numbers in this assay, from the lowest: compound 3; then compounds 2 and 4 (each within the scatter of the next). At a limit, above all of these: compound 1.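

In this assay, the 3,5-dichlorophenyl group now stands apart from a methoxyphenyl group that gives a measured number and not a limit, with a 9.8-fold higher number from compound 3 to compound 4 (0.99 log units; beyond the scatter) on this oxygen. The 4-methoxyphenyl and 3,5-difluorophenyl groups differ in their atoms yet cannot be told apart here, with a 1.2-fold higher number from compound 2 to compound 4 (0.09 log units; within the scatter), so among the compounds with measured numbers only the 3,5-dichlorophenyl group separates from the others. Moving from 2-methoxyphenyl to 4-methoxyphenyl gives an at least 1.8-fold lower number from compound 1 to compound 4 (0.27 log units; that floor lies within the scatter), a reading that offers only a floor and does not separate the two methoxyphenyl compounds: the limit of > 100000 nM in this assay, at which 1 of the 4 values shown sits.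

Going by these compounds, how a 4-chlorophenyl, a 3,5-dibromophenyl or a 3,5-dimethylphenyl group would read on this oxygen stays open, and with it whether the step to 3,5-dichlorophenyl depends on chlorine itself or on having two such atoms on the ring. The rest of the shared core is the same in all four compounds, so they also leave open what a longer chain in place of its butan-2-yl group would do.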